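The source may hold more compounds than are shown below. What is called first, only, known or untested is meant among the compounds shown, and "the series" means these compounds.

Cytotoxicity sets a ceiling on how much of a compound cells can tolerate, and here it was measured in an ADME assay on MT4 cells (Homo sapiens) for cytotoxicity, read by MTT assay; a higher number here means that more compound is tolerated, a lower number that less compound is tolerated. Compound 1, `COc1cccc2c1c(C(=O)/C=C(\O)C(=O)O)cn2Cc1cccc(F)c1`, gives 65800 nM in this assay. Of the three numbers available it is the highest, yet the gaps to both other compounds fall within the scatter, so nothing separates them. Compound 3, `CCOC(=O)/C(O)=C/C(=O)c1cn(Cc2cccc(F)c2)c2cccc(OC)c12`, gives 63200 nM; the step of a 1.0-fold lower number from compound 1 to compound 3 (0.02 log units; within the scatter). Compound 2, `CCOC(=O)/C(O)=C/C(=O)c1cn(Cc2c(F)ccc(F)c2F)c2cccc(OC)c12`, gives 40500 nM; the step of a 1.6-fold higher number from compound 2 to compound 3 (0.19 log units; within the scatter).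

The step that matters now is from compound 1 to compound 4, `COc1cccc2c1c(C(=O)/C=C(\O)C(=O)O)cn2Cc1cc(F)cc(F)c1`. The change is fluoro in place of hydrogen on an aromatic carbon, taking the benzyl group from 3-fluorobenzyl to 3,5-difluorobenzyl. Among the compounds with values here, the closest precedent is the step from compound 2 to compound 3, where the number of fluorines on that same benzyl ring changed and this assay barely moved. The ester step from compound 1 to compound 3 likewise stayed within the scatter. Adding a single fluoro is therefore expected to produce no step beyond the scatter, with compound 4 expected to land near compound 1 at an estimated 60000 nM, between 30000 nM and 120000 nM, an expected step of a 1.1-fold lower number from compound 1 to compound 4 (0.04 log units; within the scatter).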

Compound 4, half-maximal cytotoxic concentration: 29500 nM
Compound 4: the middle estimate sits 2.0-fold (0.31 log units) above what was measured; the whole stated range lies above it.
By their numbers in this assay, from the lowest: compounds 4, 2, 3 and 1 (each within the scatter of the next, the first and the last beyond it).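

In this assay, within the data shown here, fluoro in place of hydrogen on an aromatic carbon, turning 3-fluorobenzyl into 3,5-difluorobenzyl, gives a 2.2-fold lower number from compound 1 to compound 4 (0.35 log units; beyond the scatter), and this modest change is the first single-place step here to lie beyond the scatter. It shows that cell tolerance can respond to this one added atom on the benzyl ring, which the earlier comparison did not reveal: the step between 2,3,6-trifluorophenyl and 3-fluorophenyl, a 1.6-fold higher number from compound 2 to compound 3 (0.19 log units; within the scatter), stayed within the scatter, so compound 2 and compound 3 go against any simple rule that more fluorines on this ring mean less compound is tolerated. Nothing measured here accounts for the step.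

On these data alone, it remains open whether this effect is specific to fluoro at this ring carbon, since a chloro group, a methyl group or an amine in the same place would test that directly. As far as these compounds go, it is also open whether the same fluoro step would appear with ethyl on the oxygen next to the carbonyl group, a change that on its own gave only a 1.0-fold lower number from compound 1 to compound 3 (0.02 log units; within the scatter).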